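A few compounds are considered here, and "the series" means these few. Any claim that something is new, unique, unknown or untested is made for them only; others in the source may bear on it.

In a functional assay on HepG2 cells (Homo sapiens) for inhibition, read by MTT assay, with a stated time of 48 h (a lower number here means a stronger inhibitor, a higher number a weaker inhibitor), compound 1 (`O=C(Nc1cccc(Cl)c1)Nc1ccc(-c2cc(=O)c3ccccc3o2)c(Cl)c1`) gives 9700 nM while compound 2 (`CCc1ccc2oc(-c3ccc(NC(=O)Nc4cccc(Cl)c4)cc3Cl)cc(=O)c2c1`) gives 30700 nM and compound 3 (`CCc1ccc2oc(-c3ccc(NC(=O)Nc4ccc(Cl)cc4)cc3Cl)cc(=O)c2c1`) gives 8300 nM so compound 2 has the highest number of the three and is the weakest inhibitor among them. Compound 4 (`O=C(Nc1cccc(Cl)c1)Nc1ccc(-c2cc(=O)c3cc(F)ccc3o2)c(Cl)c1`) differs from compound 2 by having fluoro in place of ethyl on an aromatic carbon. The closest measured change is a 3.2-fold higher number from compound 1 to compound 2 (0.50 log units; beyond the scatter) when ethyl took the place of hydrogen, so compound 4, which also lacks the ethyl, may be expected to move back the other way. Compound 4 keeps the 3-chlorophenyl of compound 2, so the swap to 4-chlorophenyl, a 3.7-fold lower number from compound 2 to compound 3 (0.57 log units; beyond the scatter) serves only as a guide to how large one change can be in this small set. For the measured compounds named here, no measured compound carries fluoro, which leaves the size uncertain. In this assay a lower number is expected, with an estimated change of a 2.6-fold lower number from compound 2 to compound 4 (0.41 log units; beyond the scatter) as the likely outcome. Compound 4 is estimated at 12000 nM (expected range 5000 nM to 28000 nM).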

Compound 4, half-maximal inhibitory concentration: 31700 nM
Compound 4: the middle estimate sits 2.6-fold (0.42 log units) below what was measured, and the stated range ends below it.
By their numbers in this assay, from the lowest: compounds 3 and 1 (each within the scatter of the next); then compounds 2 and 4 (each within the scatter of the next).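

In this assay, fluoro in place of ethyl gives a 1.0-fold higher number from compound 2 to compound 4 (0.01 log units; within the scatter), so these two groups cannot be told apart at this position, even though fluoro has one heavy atom and ethyl has two. Fluoro in place of hydrogen gives a 3.3-fold higher number from compound 1 to compound 4 (0.51 log units; beyond the scatter), which means that among the compounds with the 3-chlorophenyl group, both substituents tested on this aromatic carbon give a weaker inhibitor than hydrogen does, not just ethyl. Nothing available here explains why fluoro and ethyl read alike.

On these data alone, it remains open whether hydrogen would also give the stronger inhibitor alongside the 4-chlorophenyl group of compound 3. The compounds shown also leave open how a methoxy group or an amine would behave at this same position.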